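Cyclohexyl for Methylphenyl on the Hydroxy-Bearing Carbon

The compounds below may be only part of what the source reports. "The series", "measured", "known", "first", "only" and "open" are said of these compounds alone.

Compound 1 `Cc1cccc([C@@H](O)C(=O)N2N=CC[C@H]2C(=O)NCc2cc(Cl)ccc2-n2cnnn2)c1` gives 830 nM in a functional assay on a cell-free system (plasma, Homo sapiens), with a stated time of 3 min (on this read-out higher numbers stand for weaker inhibition and lower numbers for stronger inhibition), the lowest of the two numbers at hand. Compound 2 `CC(C)(C)[C@@H](O)C(=O)N1[C@H](C(=O)NCc2cc(Cl)ccc2-n2cnnn2)C[C@@H]2C[C@@H]21`, built on a different core, gives 1500 nM in this assay; the two values lie within the scatter of each other. Compound 3 `O=C(NCc1cc(Cl)ccc1-n1cnnn1)[C@@H]1CC=NN1C(=O)[C@H](O)C1CCCCC1` differs from compound 1 in one place: cyclohexyl in place of 3-methylphenyl on a saturated chain carbon bound to a carbonyl carbon and an oxygen on a saturated carbon. Within the data shown here, no pair that differs in one place has been measured, so no step of that kind is known. Compound 3 is expected to stay within the scatter of compound 1, with a step of a 1.2-fold higher number from compound 1 to compound 3 (0.08 log units; within the scatter), and is estimated at 1000 nM, between 300 nM and 3000 nM.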

Compound 3, half-maximal inhibitory concentration: 970 nM
Estimate against measurement, compound 3: 1.0-fold (0.01 log units) above, and the stated range covers the measured number.
By their numbers in this assay, from the lowest: compounds 1, 3 and 2 (each within the scatter of the next).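

On the carbon bearing the hydroxy group, the core of compound 1 takes cyclohexyl in place of 3-methylphenyl with a step in this assay of a 1.2-fold higher number from compound 1 to compound 3 (0.07 log units; within the scatter). This first single-place comparison shows that, for this pair, an aromatic ring at this position is not needed to keep the number within the scatter. Nothing at hand accounts for this result.

As far as these compounds go, it remains open how this position would respond to an amine or a carboxylic acid on the ring, or to a longer chain in its place.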